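The source may report more compounds than this note shows. Statements on the series, on what has been measured and on what is new or still open speak of the compounds shown alone.

In a functional assay on the whole organism with Mus musculus as the target (a higher number here means a larger maximal response, a lower number a smaller maximal response), compound 1 `Nc1nc(O)c2c(n1)n(C1OC(CO)[C@@H](O)[C@H]1O)c(=O)n2Cc1ccc(Cl)c(Cl)c1` gives 0%. Compound 2 `C=CCn1c(=O)n(C2CCC(CO)C2)c2nc(N)nc(O)c21` gives 0%, so compound 1 and compound 2 sit level at the bottom of the three numbers, while compound 3 `C=CCn1c(=O)n(CCCC)c2nc(N)nc(O)c21` gives 36%, the highest of the three. Among the compounds with values here, the only measured step that changes one place, a number 36 percentage points higher from compound 2 to compound 3 (beyond the scatter), swaps a ring-bearing group for a short chain on an aromatic nitrogen.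

Compound 4 `Nc1nc(O)c2c(n1)n(C1OC(CO)[C@@H](O)[C@H]1O)c(=O)n2CCN1CCCCC1` is obtained from compound 1 by one change: (piperidin-1-yl)methyl in place of 3,4-dichlorophenyl on a saturated chain carbon bound to an aromatic nitrogen. Within the data shown here, this change sits on a saturated chain carbon bound to an aromatic nitrogen, which is not the place altered between compound 2 and compound 3, so no measured step speaks to it directly. Compound 1 and compound 4 share the sugar-bearing core of compound 1, and both compounds that carry it, compound 1 and compound 2, show the lowest value. The expectation for compound 4 is therefore a small step, a number 10 percentage points higher from compound 1 to compound 4 (within the scatter), with no firm direction. In this assay compound 4 is estimated at 10%, with a range from 0% to 40%.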

Compound 4, largest response reached (reported as maximal response), in percent of the reference or control that the assay uses: 0%
Beside the measured number, compound 4's estimate is 10 percentage points above it, within the range that was stated.
By their numbers in this assay, from the lowest: compounds 1, 2 and 4 (each within the scatter of the next); then compound 3.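

In this assay the step is no change at the digits printed from compound 1 to compound 4 (within the scatter) when (piperidin-1-yl)methyl takes the place of 3,4-dichlorophenyl on a saturated chain carbon bound to an aromatic nitrogen. Within the data shown here, this is the first reading of a change at this place: on the core of compound 1, an aromatic ring of carbon carrying two chlorines and a non-aromatic ring holding one nitrogen give the same result, and neither brings a response into view. No measurement here offers an explanation for this result. On these data alone, what stays open is whether any group at this place can raise the response on this core, such as a carboxylic acid or a longer unbranched carbon chain. A reading with no response also cannot show whether either group tested would lower it.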